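Swapping cyclobutyl for tert-butyl on one compound

The source may report more compounds than this note shows. Statements on the series, on what has been measured and on what is new or still open speak of the compounds shown alone.

In a physicochemical assay for lipophilicity, using the shake flask method, at pH 7.4 (a lower number here means a more polar compound, a higher number a more lipophilic compound), compound 1 (`CCCC(Nc1ccc(-n2cc(C(F)(F)F)cn2)nc1)c1ccc(C(=O)NCCC(=O)O)cc1`) gives 2.1 and compound 3 (`CCCC(Nc1cc(C)c(-n2cc(C(F)(F)F)cn2)c(C)c1)c1ccc(C(=O)NCCC(=O)O)cc1`) gives 2.2 as its reading. Compound 2 (`O=C(O)CCNC(=O)c1ccc(C(Oc2ccc(-n3cc(C(F)(F)F)cn3)cc2)C2CCC2)cc1`) gives 2.6 and holds the highest of the three numbers, with both others lower by more than the usual scatter of repeat measurements. Compound 4 (`CC(C)(C)C(Oc1ccc(-n2cc(C(F)(F)F)cn2)cc1)c1ccc(C(=O)NCCC(=O)O)cc1`) has not been measured yet. It differs from compound 2 in one place: tert-butyl in place of cyclobutyl on a saturated chain carbon bound to an aromatic carbon and an oxygen on an aromatic ring. Both groups are made of carbon only and carry no net charge, and what disappears is the four-membered ring. For the measured compounds named here, no measured pair here shows a change of this kind, so the expectation rests on the structures alone. A small upward step in this assay is expected, one that stays within the scatter. The estimated move is a number 0.10 log units higher from compound 2 to compound 4 (within the scatter) on this scale. For compound 4 the estimated value is 2.7 with an expected range from 2.3 to 3.1 on the same scale.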

Compound 4, distribution coefficient: 3.7
Estimate against measurement, compound 4: 1.00 log units below; measured number outside the range, above it.
By their numbers in this assay, from the lowest: compounds 1 and 3 (each within the scatter of the next); then compound 2; then compound 4.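

In this assay, tert-butyl in place of cyclobutyl gives a number 1.10 log units higher from compound 2 to compound 4 (beyond the scatter). The two groups match in everything counted here: each has 4 carbons, no hydrogen-bond donors or acceptors and no net charge, and only the four-membered ring is lost. So at this position, on a saturated chain carbon bound to an aromatic carbon and an oxygen on an aromatic ring, rearranging the same carbons is enough to move the reading by a large step, though nothing in the data accounts for its size.

An isopropyl or cyclopentyl group at this place could show whether the reading follows the loss of the ring or something particular to tert-butyl. From the compounds shown here alone, whether the same swap gives a similar step on the core of compound 1 also remains open.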